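From Benzylamide to Piperidine Amide in Paw Edema

A few compounds are considered here, and "the series" means these few. Any claim that something is new, unique, unknown or untested is made for them only; others in the source may bear on it.

Three amides built on one shared core have been tested in a functional assay on the whole organism (strain Wistar) for inhibition, with Rattus norvegicus as the target, read by paw edema, with stated times of 60 min and 24 h, at a dose of 100 mg/kg by the oral route; on this read-out lower numbers stand for less inhibition and higher numbers for more inhibition at the one dose given (going by the name of the read-out). Compound 1 `CCNC(=O)CC1CCc2cc(OC)c(OC)cc21` gives 33.3%. Compound 2 `CCCCNC(=O)CC1CCc2cc(OC)c(OC)cc21` gives 36.7%, and compound 3 `COc1cc2c(cc1OC)C(CC(=O)NCc1ccccc1)CC2` gives 43.3%. Compound 3 stands at the highest of the three numbers, yet every gap to the others stays within the usual spread of repeated measurements: the step of a number 10 percentage points higher from compound 1 to compound 3 (within the scatter), the step of a number 6.6 percentage points higher from compound 2 to compound 3 (within the scatter) and the step of a number 3.4 percentage points higher from compound 1 to compound 2 (within the scatter) are all too small to separate the compounds in this assay .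

Compound 4 `COc1cc2c(cc1OC)C(CC(=O)N1CCCCC1)CC2` has not been measured. It differs from compound 3 in one place: piperidin-1-yl in place of benzylamino on a carbonyl carbon. Going by the values given here, no measured step covers exactly this kind of change. The three measured steps each replace one open-chain group on the amide nitrogen by another, and none of them moves the number beyond the scatter. Going by that pattern, the expected step of a number 3.3 percentage points lower from compound 3 to compound 4 (within the scatter) is small and without a clear direction, although the change to a ring that closes off the amide nitrogen is of a different kind from the steps measured so far. Compound 4 is therefore estimated at 40% in this assay , with a range from 25% to 55%.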

Compound 4, a percentage reported as inhibition, in the whole organism at one dose (the size of the read-out at that dose, not a potency): 40%
Compound 4: the middle estimate sits on the measured number at the digits printed; the measured number falls inside the stated range.
By their numbers in this assay, from the lowest: compounds 1, 2, 4 and 3 (each within the scatter of the next).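

On the carbonyl carbon, the amide hydrogen can be lost without the number leaving the scatter: benzylamino carries 1 hydrogen-bond donor and piperidin-1-yl carries 0, and this assay shows a number 3.3 percentage points lower from compound 3 to compound 4 (within the scatter). The comparison with the two open-chain groups reads the same way, with a number 3.3 percentage points higher from compound 2 to compound 4 (within the scatter) for butylamino and a number 6.7 percentage points higher from compound 1 to compound 4 (within the scatter) for ethylamino, so a ring that closes off the nitrogen cannot be told apart from any of the three open-chain groups at this one dose. Nothing available here explains why these four numbers lie so close together.

All four groups on the carbonyl carbon shown so far carry no net charge, which leaves open whether a carboxylic acid at this place, or an amide with a dimethylamino group at the end of its chain, would move the number beyond the scatter. From the compounds shown here alone, it also remains open whether morpholin-4-yl would behave like piperidin-1-yl, and whether changing the methoxy groups on the shared core would matter more than anything changed on the carbonyl carbon.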